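The compounds below may be only part of what the source reports. "The series", "measured", "known", "first", "only" and "open" are said of these compounds alone.

In a functional assay on U-937 cells (Homo sapiens) for antiproliferative activity, read by MTT assay, with a stated time of 72 h (a higher number here means a weaker inhibitor, a lower number a stronger inhibitor), compound 1 `Cc1ccc(-c2noc(CCCCCCC(=O)NO)n2)cc1` gives 1360 nM and compound 2 `O=C(CCCCCCc1nc(-c2ccc(F)cc2)no1)NO` gives 1930 nM so these two compounds stand within the usual scatter of each other. Among the compounds with values here, with only two numbers available, compound 2 has a single neighbour and neither compound can be ranked above the other.

Compound 3 `O=C(CCCCCCc1nc(-c2ccccc2Cl)no1)NO` differs from compound 2 in one place, with 2-chlorophenyl in place of 4-fluorophenyl on an aromatic carbon of the shared core: 2-chlorophenyl in place of 4-fluorophenyl on an aromatic carbon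

Within the data shown here, the only measured step that bears on this is a 1.4-fold higher number from compound 1 to compound 2 (0.15 log units; within the scatter) and it also exchanges a group on the six-membered aromatic ring, fluoro in place of methyl. Among the measured compounds shown here, that step is only a thin guide, as no measured compound carries 2-chlorophenyl. On this evidence no shift beyond the scatter is expected in this assay and no direction can be favoured with confidence. The expected size is a 1.1-fold lower number from compound 2 to compound 3 (0.06 log units; within the scatter) and it rests on very little data. Compound 3 is therefore expected to give about 1700 nM (estimated range 750 nM to 3900 nM).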

Compound 3, half-maximal inhibitory concentration: 750 nM
For compound 3 the middle estimate is 2.3-fold (0.36 log units) above the measured one; the measured number falls inside the stated range.
By their numbers in this assay, from the lowest: compounds 3, 1 and 2 (each within the scatter of the next, the first and the last beyond it).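

In this assay, the aryl group on this aromatic carbon of the shared core now gives a step beyond the scatter, though a modest one: 2-chlorophenyl in place of 4-fluorophenyl gives a 2.6-fold lower number from compound 2 to compound 3 (0.41 log units; beyond the scatter), whereas the earlier exchange of fluoro for methyl did not separate compound 1 and compound 2. The result is not a clean gain over both earlier compounds, since 2-chlorophenyl in place of 4-methylphenyl gives a 1.8-fold lower number from compound 1 to compound 3 (0.26 log units; within the scatter), so compound 3 stands apart from compound 2 only. The change to compound 3 alters both the atom on the phenyl ring and where that atom sits, and no measurement available here explains the shift.

What the compounds shown leave open is whether the chlorine or its place on the ring carries the step, a question that 4-chlorophenyl and 2-fluorophenyl would help to settle. Also open, as far as these compounds go, is how a plain phenyl, a 2-methylphenyl or a 2-methoxyphenyl would behave at this position, and whether a shorter or longer chain would change the picture.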